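From 3-Fluorophenyl to 4-Methoxyphenyl on a Shared Core

A few compounds are considered here, and "the series" means these few. Any claim that something is new, unique, unknown or untested is made for them only; others in the source may bear on it.

Measured in a functional assay (aorta) with Oryctolagus cuniculus as the target; a higher number here means a weaker inhibitor, a lower number a stronger inhibitor:
- Compound 1 `CC1=C(C)C(=O)C(C(CCCCCC(=O)O)c2ccc(C)cc2)=C(C)C1=O` gives 1000 nM
- Compound 2 `CC1=C(C)C(=O)C(C(CCCCCC(=O)O)c2ccc(F)cc2)=C(C)C1=O` gives 48 nM
- Compound 3 `CC1=C(C)C(=O)C(C(CCCCCC(=O)O)c2cccc(F)c2)=C(C)C1=O` gives 1900 nM

Compound 3 shares the weak end of this small set with compound 1: a 1.9-fold higher number from compound 1 to compound 3 (0.28 log units; within the scatter) stays within the scatter. The a 40-fold higher number from compound 2 to compound 3 (1.60 log units; beyond the scatter) is large, so compound 2 stands well apart from both.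

Compound 4 `COc1ccc(C(CCCCCC(=O)O)C2=C(C)C(=O)C(C)=C(C)C2=O)cc1` changes one group of compound 3 (4-methoxyphenyl in place of 3-fluorophenyl on a saturated chain carbon bound to a double-bonded ring carbon and a saturated chain carbon). 4-Methoxyphenyl takes the place of 3-fluorophenyl on a saturated chain carbon bound to a double-bonded ring carbon and a saturated chain carbon.

Among the compounds with values here, no measured compound carries 4-methoxyphenyl, so the guidance is indirect. The a 21-fold lower number from compound 1 to compound 2 (1.32 log units; beyond the scatter) is also large, which shows that a single swap on this ring can move the number a long way. The closest group by name and size is the 4-methylphenyl of compound 1, at 1000 nM, while the 4-fluorophenyl of compound 2 reaches 48 nM. A moderate drop is therefore expected, with wide uncertainty in either direction.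

The expected change is a 3.8-fold lower number from compound 3 to compound 4 (0.58 log units; beyond the scatter).

For compound 4 the estimated value is 500 nM, with an expected range of 60 nM to 3000 nM.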

Compound 4, half-maximal inhibitory concentration: 3000 nM
Beside the measured number, compound 4's estimate is 6.0-fold (0.78 log units) below it, and the stated range covers the measured number.
By their numbers in this assay, from the lowest: compound 2; then compounds 1, 3 and 4 (each within the scatter of the next, the first and the last beyond it).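

In this assay, the step to the 4-methoxyphenyl group, a 1.6-fold higher number from compound 3 to compound 4 (0.20 log units; within the scatter), is too small to separate it from the 3-fluorophenyl group, so these two different groups cannot be told apart here. The clearer reading comes from comparing groups on the same aromatic carbon: methoxy in place of fluoro gives a 63-fold higher number from compound 2 to compound 4 (1.80 log units; beyond the scatter), a large step, while methoxy in place of methyl gives a 3.0-fold higher number from compound 1 to compound 4 (0.48 log units; beyond the scatter), a modest one, which leaves compound 2 alone at the strong end of the set. Nothing available here explains why the fluoro group of compound 2 stands so far apart.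

Going by these compounds, whether chloro or hydroxy on that aromatic carbon would bring the number near that of compound 2 remains open. So does whether a 3-methoxyphenyl group would match the 3-fluorophenyl group of compound 3.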